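Chloro for methyl on the sulfonyl aryl: expected potency

A few compounds are considered here, and "the series" means these few. Any claim that something is new, unique, unknown or untested is made for them only; others in the source may bear on it.

Compound 1 `COc1ccc(Cc2nnc(CN(c3cccc(Cl)c3C)S(=O)(=O)c3ccc(C)cc3)o2)cc1` is the reference point; in an assay on CHO cells for displacement of a labelled ligand from prostaglandin E2 receptor EP1 subtype (Homo sapiens) (a lower number here means a stronger inhibitor, a higher number a weaker inhibitor), compound 1 gives 6.31 nM. Compound 2 `COc1ccc(Cc2nnc(CN(c3cccc(Cl)c3Cl)S(=O)(=O)c3ccc(C)cc3)o2)cc1` carries chloro in place of methyl on an aromatic carbon and in this assay compound 2 gives 7.94 nM. The step of a 1.3-fold higher number from compound 1 to compound 2 (0.10 log units; within the scatter) stays within the scatter. Of the two numbers measured, that of compound 2 is the higher, but the gap to compound 1 lies within the scatter, so no order is drawn. Compound 3 `COc1ccc(Cc2nnc(CN(c3cccc(Cl)c3Cl)S(=O)(=O)c3ccc(Cl)cc3)o2)cc1` is not yet measured; it differs from compound 2 by chloro in place of methyl on an aromatic carbon. Within the data shown here, the only measured step bearing on this is the same exchange at another site, a 1.3-fold higher number from compound 1 to compound 2 (0.10 log units; within the scatter), which did not move the number beyond the scatter. The expected step is therefore a 1.1-fold higher number from compound 2 to compound 3 (0.05 log units; within the scatter), with no direction beyond the scatter. For compound 3 the expected value in this assay is 9 nM, within a range of 4 nM to 22 nM.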

Compound 3, half-maximal inhibitory concentration: 20 nM
Compound 3: middle estimate off by 2.2-fold (0.35 log units), on the low side; the measured number falls inside the stated range.
By their numbers in this assay, from the lowest: compounds 1 and 2 (each within the scatter of the next); then compound 3.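

In this assay, the sulfonyl aryl proves sensitive to this exchange: going from (4-methylphenyl)sulfonyl to (4-chlorophenyl)sulfonyl gives a 2.5-fold higher number from compound 2 to compound 3 (0.40 log units; beyond the scatter), a modest weakening that lies beyond the scatter. The same exchange at the other aryl gave a 1.3-fold higher number from compound 1 to compound 2 (0.10 log units; within the scatter), within the scatter, so across these two pairs, chloro in place of methyl does not read the same at both sites. Nothing available explains the difference between the two sites.

The compounds shown leave open whether the 4-methylphenyl step would be the same size with the methyl of compound 1 on the other aryl. They also leave open whether the weakening follows from the loss of methyl or the entry of chloro, and how a methoxy, an amine or a longer chain would read at this place.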